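Methoxy for methyl on the benzyl group

The source may hold more compounds than are shown below. What is called first, only, known or untested is meant among the compounds shown, and "the series" means these compounds.

Compound 3 `Cc1ccc(CN2CCC(C(=O)Nc3ccc(CNc4nc(N(C)C)nc5cc(C)ccc45)cc3)CC2)cc1` carries the 4-methylbenzyl group of the series. In a functional assay on SV5A8 cells (Homo sapiens) for cytotoxicity (on this read-out lower numbers stand for stronger inhibition and higher numbers for weaker inhibition), compound 3 gives only a limit, > 4150 nM. Compound 1 `Cc1ccc2c(NCc3ccc(NC(=O)C4CCN(Cc5ccc(F)cc5)CC4)cc3)nc(N(C)C)nc2c1` is the fluoro analogue, and in this assay compound 1 likewise gives only a limit, > 4820 nM. Compound 2 `Cc1ccc2c(NCc3ccc(NC(=O)C4CCN(Cc5ccc(Cl)cc5)CC4)cc3)nc(N(C)C)nc2c1` is the chloro analogue; in this assay compound 2 also gives only a limit, > 3180 nM. All three results are limits, so compound 3 cannot be placed above or below the others; (the limit of > 3180 nM in this assay, at which 1 of the 3 values shown sits), the limit of > 4150 nM in this assay, at which 1 of the 3 values shown sits, and the limit of > 4820 nM in this assay, at which 1 of the 3 values shown sits, mark where the three values sit.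

The change to compound 4 `COc1ccc(CN2CCC(C(=O)Nc3ccc(CNc4nc(N(C)C)nc5cc(C)ccc45)cc3)CC2)cc1` is methoxy in place of methyl on an aromatic carbon. The measured steps that bear on this position are a step that the two limits leave unreadable from compound 1 to compound 2, a step that the two limits leave unreadable from compound 1 to compound 3 and a step that the two limits leave unreadable from compound 2 to compound 3; none of them has a readable size, as every value involved is a limit. Nothing measured here separates one substituent at this position from another. The expectation for this assay is therefore that compound 4 stays at the limit as well, with no step beyond the scatter; the estimated step is a step that the limit leaves unreadable from compound 3 to compound 4. The estimate for compound 4 is 5000 nM, with a range from 1500 nM to 20000 nM, and the assay is expected to report only a limit again.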

Compound 4, half-maximal inhibitory concentration: > 6180 nM
Compound 4: only a limit was reported; the forecaster's own chance of this, stated with the estimate: 85%; middle value at least 1.2-fold (0.09 log units) away from the limit.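

Compound 4 gives only a limit in this assay, > 6180 nM. Going by these compounds alone, no step from compound 1, compound 2 or compound 3 to compound 4 can be read; all four results are limits. The compounds shown leave open whether fluoro, chloro, methyl and methoxy on the benzyl group differ at all on this read-out.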